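This account rests on a few compounds, and the source may have more. Where it says the series, first, only, none or still open, it means among the compounds named here.

In an ADME assay on HEK293 cells (Homo sapiens) for cytotoxicity, with a stated time of 6 h (on this read-out lower numbers stand for higher toxicity in this test and higher numbers for lower toxicity in this test), compound 1 `CCCCNc1nc(N)nc2ccc(CCc3ccccn3)cc12` gives > 18000 nM, and this is a limit of the assay, not a number. Among the measured compounds shown here, compound 2 `CCCCNc1nc(N)nc2cccc(Cl)c12` gives 100 nM, the only actual number so far, and it lies well toward the toxic end of what has been seen in this assay. Compound 3 `CCCCNc1nc(N)nc2cccc(OCCOC)c12` keeps the core of compound 2 and carries 2-methoxyethoxy in place of chloro on an aromatic carbon. For the measured compounds named here, no step between measured compounds shows what such a swap does, so the expectation is a judgement with wide uncertainty: a moderate rise in the number, beyond the usual scatter, meaning lower toxicity in this test. The estimated step is a 5.0-fold higher number from compound 2 to compound 3 (0.70 log units; beyond the scatter). Compound 3 is expected at 500 nM, with an estimated range from 70 nM to 6000 nM.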

Compound 3, half-maximal cytotoxic concentration: 10000 nM
The estimate for compound 3 lay 20-fold (1.30 log units) below the measured number; measured number outside the range, above it.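

In this assay, this aromatic carbon proves highly sensitive to the group it carries: with the rest of compound 2 unchanged, putting 2-methoxyethoxy in place of chloro gives a 100-fold higher number from compound 2 to compound 3 (2.00 log units; beyond the scatter). Among the compounds shown here, the earlier compounds differed in more than one place and offered no such step, so this is the first direct reading of a single change at this position. The number for compound 3 is a measured one, whereas compound 1 sits at a limit: the limit of > 18000 nM in this assay, at which 1 of the 3 values shown sits.

The compounds shown do not separate the loss of chloro from the gain of 2-methoxyethoxy, as neither a plain hydrogen nor a methoxy group at this position is among them. As far as these compounds go, how a longer ether chain or a chain ending in an amine would read here also remains open.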